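Swapping the furan for a methoxyphenyl on the shared core

The compounds below may be only part of what the source reports. "The series", "measured", "known", "first", "only" and "open" are said of these compounds alone.

Compound 1 `COc1ccc(-c2cc(-c3cc(C(C)C)c(O)cc3C)[nH]c(=O)c2C#N)c(OC)c1`: 58%
Compound 2 `Cc1cc(O)c(C(C)C)cc1-c1cc(-c2cccs2)c(C#N)c(=O)[nH]1`: 68%
Compound 3 `Cc1cc(O)c(C(C)C)cc1-c1cc(-c2ccco2)c(C#N)c(=O)[nH]1`: 70%

In a functional assay for inhibition, tested at 100 ug/mL (a higher number here means a stronger effect of the compound at the concentration tested, a lower number a weaker effect), compound 3 gives the highest of the three numbers; compound 2 sits within the scatter of it, while compound 1 lies beyond the scatter below it. Compound 4 `COc1ccc(-c2cc(-c3cc(C(C)C)c(O)cc3C)[nH]c(=O)c2C#N)cc1` differs from compound 3 by 4-methoxyphenyl in place of furan-2-yl on an aromatic carbon. The step that bears on this is a number 12 percentage points higher from compound 1 to compound 3 (beyond the scatter), where furan-2-yl replaced 2,4-dimethoxyphenyl; the present change runs the other way, back toward a methoxy-bearing phenyl. A modest fall in this assay is therefore expected. Compound 4 is expected to give 60%, with a range from 45% to 75%. The expected step is a number 10 percentage points lower from compound 3 to compound 4 (within the scatter).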

Compound 4, a percentage reported as inhibition, at one concentration (the size of the read-out at that concentration, not a potency): 54%
The estimate for compound 4 lay 6 percentage points above the measured number, within the range that was stated.
By their numbers in this assay, from the lowest: compounds 4, 1, 2 and 3 (each within the scatter of the next, the first and the last beyond it).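

In this assay, 4-methoxyphenyl in place of furan-2-yl gives a number 16 percentage points lower from compound 3 to compound 4 (beyond the scatter) and in place of thiophen-2-yl gives a number 14 percentage points lower from compound 2 to compound 4 (beyond the scatter) here, so both five-membered rings now stand clear of this phenyl group. Hydrogen in place of methoxy gives a number 4 percentage points lower from compound 1 to compound 4 (within the scatter) and so separates neither methoxyphenyl compound from the other. Nothing measured here explains these steps.
The compounds shown leave open how an unsubstituted phenyl or a pyridine ring would read at this position, and whether an amine or a carboxylic acid on the phenyl ring would change the number.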